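Chloro to Methoxy: Expected Electroshock Inhibition for Compound 4

The source may hold more compounds than are shown below. What is called first, only, known or untested is meant among the compounds shown, and "the series" means these compounds.

Compound 1, `CN(C=O)c1ncnc2c1ncn2Cc1ccccc1`: 0%
Compound 2, `CN(C)c1ncnc2c1ncn2Cc1cccc(OCc2ccccc2)c1`: 33%
Compound 3, `CN(C)c1ncnc2c1ncn2Cc1ccccc1Cl`: 84%

Of the compounds shown here, three of one series have been tested in a functional assay on the whole organism for inhibition, with Rattus norvegicus as the target, in the maximal electroshock model, at a dose of 25 mg/kg by the intraperitoneal route; a lower number here means less inhibition, a higher number more inhibition at the dose given (going by the name of the read-out). Compound 1 shows 0%, and compound 2 shows 33%. Compound 3 stands highest of the three numbers, at 84%; the nearest, compound 2, sits below it by a gap beyond the scatter, and compound 1 lies further still, also beyond the scatter. Among the measured compounds shown here, no pair of these three differs in only one place, so the gaps between them cannot be tied to a single structural change.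

The next compound, compound 4 `COc1ccccc1Cn1cnc2c(N(C)C)ncnc21`, differs from compound 3 by methoxy in place of chloro on an aromatic carbon. For the measured compounds named here, since no single-change step has been measured, the size of the step can only be expected, not read off. The account expects a downward step in this assay from compound 3 to compound 4, of moderate size, because compound 3 reaches 84% and the series otherwise gives lower numbers. The expected step from compound 3 to compound 4 is a number 29 percentage points lower from compound 3 to compound 4 (beyond the scatter). For compound 4 the estimated inhibition is 55%, within a range from 20% to 90%.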

Compound 4, a percentage reported as inhibition, in the whole organism at one dose (the size of the read-out at that dose, not a potency): 0%
For compound 4 the middle estimate is 55 percentage points above the measured one; measured number outside the range, below it.
By their numbers in this assay, from the lowest: compounds 1 and 4 (each within the scatter of the next); then compound 2; then compound 3.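

In this assay, among the compounds shown here, methoxy in place of chloro on an aromatic carbon, ortho to a large group, gives the only single-change step that can be read: a number 84 percentage points lower from compound 3 to compound 4 (beyond the scatter). The step shows that the read-out at the dose given depends strongly on which of these two groups sits at this position, since compound 4 gives 0% while the rest of its structure stays as in compound 3. No measurement at hand bears on why this exchange has so large an effect.

The compounds shown leave open whether this step belongs to methoxy itself or would recur with other groups on the same carbon, such as fluoro, methyl or an amine, and whether a longer chain such as ethoxy would read as methoxy does. They also leave open whether chloro and methoxy would differ as sharply on another carbon of the same ring, or on a compound whose shared core carries something other than the dimethylamino group.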